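Working notes: 4-formylphenyl to methyl on the shared core

The compounds below may be only part of what the source reports. "The series", "measured", "known", "first", "only" and "open" are said of these compounds alone.

Measured so far in a functional assay on SK-OV-3 cells (Homo sapiens) for inhibition, read by CCK-8 assay, with a stated time of 70 h; a lower number here means a stronger inhibitor, a higher number a weaker inhibitor:
compound 1 `O=C(O)c1ccccc1COc1ccc(OCCOCCNC2CCCC2)cc1` gives > 100000 nM (a limit)
compound 2 `COC(=O)c1cccc(COc2ccc(OCCOCCNC3CCCC3)cc2)c1` gives 45500 nM
compound 3 `O=Cc1ccc(COc2ccc(OCCOCCNC3CCCC3)cc2)cc1` gives 45000 nM
Not yet measured: compound 4 `CCOc1ccc(OCCOCCNC2CCCC2)cc1`

For the measured compounds named here, compound 3 does not separate from compound 2, the only other compound with a number (a 1.0-fold lower number from compound 2 to compound 3 (0.00 log units; within the scatter)). Compound 1 has only a limit. The steps out of it are both at least modest and beyond the scatter (an at least 2.1-fold lower number from compound 1 to compound 2 (0.34 log units; beyond the scatter) and an at least 2.2-fold lower number from compound 1 to compound 3 (0.34 log units; beyond the scatter)).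

The change to compound 4 (methyl in place of 4-formylphenyl on a saturated chain carbon bound to an oxygen on an aromatic ring) is methyl in place of 4-formylphenyl on a saturated chain carbon bound to an oxygen on an aromatic ring. All three measured steps exchange one substituted phenyl for another at this place, and none removes the ring, so they offer only indirect guidance. They do show that a change here can leave the number unmoved (a 1.0-fold lower number from compound 2 to compound 3 (0.00 log units; within the scatter)) or raise it to a limit (an at least 2.2-fold lower number from compound 1 to compound 3 (0.34 log units; beyond the scatter) read in reverse). In this assay the expected step is therefore small and leans toward a higher number, with no firm move beyond the scatter (a 1.4-fold higher number from compound 3 to compound 4 (0.16 log units; within the scatter)). For compound 4 the estimated value is 65000 nM (expected range 25000 nM to 170000 nM).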

Compound 4, half-maximal inhibitory concentration: 90500 nM
For compound 4 the middle estimate is 1.4-fold (0.14 log units) below the measured one; low and high end bracket the measured number.
By their numbers in this assay, from the lowest: compounds 3, 2 and 4 (each within the scatter of the next). At a limit, above all of these: compound 1.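

In this assay, for the compounds shown here, compound 4 is the only compound in which no ring remains at this place, on a saturated chain carbon bound to an oxygen on an aromatic ring, and methyl in place of 4-formylphenyl gives a 2.0-fold higher number from compound 3 to compound 4 (0.30 log units; within the scatter), while methyl in place of 3-(methoxycarbonyl)phenyl gives a 2.0-fold higher number from compound 2 to compound 4 (0.30 log units; within the scatter). The earlier steps shown here only swapped one substituted phenyl for another; these two show that, among compounds 2, 3 and 4, the presence of a substituted phenyl at this place does not separate from methyl. Methyl in place of 2-carboxyphenyl gives an at least 1.1-fold lower number from compound 1 to compound 4 (0.04 log units; that floor lies within the scatter), so this step does not show a separation either. Compound 1 carries only a limit of the assay: the limit of > 100000 nM in this assay, at which 1 of the 4 values shown sits.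

The compounds shown leave open whether a plain benzyl, a longer alkyl chain or an amine at this place would give a number that separates from those of compounds 2, 3 and 4 in this assay. On these data alone, the rest of the shared core stays the same throughout, so what a change there would do to the number also remains open.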